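The source may report more compounds than this note shows. Statements on the series, on what has been measured and on what is new or still open speak of the compounds shown alone.

Measured compounds:
Compound 1, `CC(NC(=O)/C=C/Oc1ccc(NC(=O)Nc2cc(C(F)(F)F)ccc2Cl)cc1)c1ccccc1` — 16100 nM
Compound 2, `CNC(=O)C#Cc1ccc(NC(=O)Nc2ccc(Cl)c(C(F)(F)F)c2)cc1` — 26400 nM
Compound 3, `CC(NC(=O)c1cccc(-c2ccc(NC(=O)Nc3ccc(Cl)c(C(F)(F)F)c3)cc2)c1)c1ccccc1` — 5240 nM

Of the compounds shown here, three built on the same diaryl urea core have been tested in a functional assay on MX1 cells (Homo sapiens) for inhibition, read by MTT assay, with a stated time of 120 h; a higher number here means a weaker inhibitor, a lower number a stronger inhibitor. Compound 2 stands at the highest of the three numbers. Its nearest neighbour is compound 1, whose value of 16100 nM lies within the scatter of that of compound 2, so the two cannot be ordered. Compound 3, at 5240 nM, lies beyond the scatter below compound 2, and is the only one of the three that separates from it. None of these three differs from another in a single place, so no isolated structural step can be read from the measured set.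

Compound 4, `CNC(=O)/C=C(\C)c1ccc(NC(=O)Nc2ccc(Cl)c(C(F)(F)F)c2)cc1`, has not yet been measured. It differs from compound 2 by 1-methyl-2-(methylcarbamoyl)ethenyl in place of 2-(methylcarbamoyl)ethynyl on an aromatic carbon. The amide end of the chain is kept; the triple bond gives way to a double bond carrying a methyl group. For the measured compounds named here, since no measured pair shows the effect of such a change on this core, the expectation rests on compound 2 alone. A small step is expected, not beyond the scatter, in the direction of a lower number, a 1.7-fold lower number from compound 2 to compound 4 (0.22 log units; within the scatter). Compound 4 is therefore estimated at 16000 nM, with a range from 5000 nM to 50000 nM.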

Compound 4, half-maximal inhibitory concentration: > 50000 nM
Compound 4: no number, only a limit (the forecaster's own chance of this, stated with the estimate: 10%); middle value at least 3.1-fold (0.49 log units) away from the limit.
By their numbers in this assay, from the lowest: compound 3; then compounds 1 and 2 (each within the scatter of the next). At a limit, above all of these: compound 4.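

In this assay compound 4 gives > 50000 nM as a limit of the assay and not as a number. For the compounds shown here, for the first time, a single change on the shared core can be read: 1-methyl-2-(methylcarbamoyl)ethenyl in place of 2-(methylcarbamoyl)ethynyl on an aromatic carbon, para to a large group, stands as an at least 1.8-fold higher number from compound 2 to compound 4 (0.27 log units; that floor lies within the scatter) and shows no lower number at this position. That step is only a floor, so the data do not say how far compound 4 lies from compound 2 or whether the two truly separate: the limit of > 50000 nM in this assay, at which 1 of the 4 values shown sits.

The methyl group and the double bond enter together in compound 4, so the compounds shown do not tell which of the two carries the step, and a plain 2-(methylcarbamoyl)ethenyl chain without the methyl group would be needed to part them. Also open, as far as these compounds go, is what an amine or a carboxylic acid in place of the methylcarbamoyl end, or a longer chain, would give at this position.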